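This account rests on a few compounds, and the source may have more. Where it says the series, first, only, none or still open, it means among the compounds named here.

In a functional assay on MCF7 cells (Homo sapiens) for inhibition, read by MTT assay, with a stated time of 72 h (on this read-out higher numbers stand for weaker inhibition and lower numbers for stronger inhibition), compound 1 (`Cc1ccc(-c2nnc(SCCCN3CCN(c4nc5ccccc5o4)CC3)o2)cc1`) gives 60400 nM and compound 2 (`O=[N+]([O-])c1ccc(-c2nnc(SCCCN3CCN(c4nc5ccccc5s4)CC3)o2)cc1`) gives 118000 nM as its reading. Going by the values given here, these two values lie within the scatter of each other, so compound 2 stands level with compound 1 on the numbers so far. Compound 3 (`Cc1ccc(-c2nnc(SCCCN3CCN(c4nc5ccccc5s4)CC3)o2)cc1`) differs from compound 2 in one place, with methyl in place of nitro on an aromatic carbon, para to a large group (methyl in place of nitro on an aromatic carbon), so 4-nitrophenyl becomes 4-methylphenyl. Among the compounds with values here, no pair of measured compounds shows this change alone. Within the data shown here, compound 1 also carries 4-methylphenyl and gives 60400 nM in this assay as the only guide, so a small move towards a lower number is expected, not beyond the scatter. The expected change a 1.7-fold lower number from compound 2 to compound 3 (0.23 log units; within the scatter) is therefore small. For compound 3 the estimated value is 70000 nM with an expected range from 25000 nM to 180000 nM for repeat measurements.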

Compound 3, half-maximal inhibitory concentration: 107000 nM
Compound 3: middle estimate off by 1.5-fold (0.18 log units), on the low side; low and high end bracket the measured number.
By their numbers in this assay, from the lowest: compounds 1, 3 and 2 (each within the scatter of the next).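

In this assay methyl in place of nitro on an aromatic carbon para to a large group gives a 1.1-fold lower number from compound 2 to compound 3 (0.04 log units; within the scatter) and so shows that going from 4-nitrophenyl to 4-methylphenyl has no readable effect at this position. Compound 1 and compound 2 differ in two places at once and could not separate the two changes, but compound 3 does: 1,3-benzothiazol-2-yl in place of 1,3-benzoxazol-2-yl on the amine nitrogen in a ring gives a 1.8-fold higher number from compound 1 to compound 3 (0.25 log units; within the scatter) and has no readable effect either. No other information is available that would account for these readings. The compounds shown leave open whether an amine or a carboxylic acid on that aromatic carbon would shift the reading beyond the scatter. They also leave open whether a simple phenyl in place of the 1,3-benzothiazol-2-yl would do so.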